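This account rests on a few compounds, and the source may have more. Where it says the series, first, only, none or still open, it means among the compounds named here.

Compound 1 `CC12CC34CC[C@H](O)[C@@](C)(CCCO)C3C(CC1C4)O2` is the bare core, and in a functional assay on A549 cells (Homo sapiens) for inhibition, read by CCK-8 assay, with a stated time of 72 h (a lower number here means a stronger inhibitor, a higher number a weaker inhibitor), compound 1 gives 35900 nM. Compound 2 `CC12CC34CC[C@H](OC(=O)c5ccc(NCc6cc(O)ccc6O)cc5)[C@@](C)(CCCOC(=O)c5ccc(NCc6cc(O)ccc6O)cc5)C3C(CC1C4)O2` carries two ester-linked side pieces on that core, and in this assay compound 2 gives 9600 nM. Compound 3 `O=C(O)c1ccc(NCc2cc(O)ccc2O)cc1` is one such side piece alone, as the free carboxy acid. For compound 3 only a limit is reported, > 100000 nM, which is the limit of > 100000 nM in this assay, at which 1 of the 3 values shown sits. Compound 4 `COC(=O)c1ccc(NCc2cc(O)ccc2O)cc1` differs from compound 3 by methyl in place of hydrogen on an oxygen next to a carbonyl group. Going by the values given here, no measured pair shows this change, so its size is unknown. The estimated step of an at least 1.2-fold lower number from compound 3 to compound 4 (0.09 log units; that floor lies within the scatter) is expected to be small, toward somewhat stronger inhibition in this assay, and compound 4 may well sit at the limit again. Compound 4 is expected to give about 80000 nM, between 30000 nM and 200000 nM.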

Compound 4, half-maximal inhibitory concentration: 23200 nM
Estimate against measurement, compound 4: 3.4-fold (0.54 log units) above; measured number outside the range, below it.
By their numbers in this assay, from the lowest: compound 2; then compounds 4 and 1 (each within the scatter of the next). At a limit, above all of these: compound 3.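

Replacing carboxy with methoxycarbonyl gives an at least 4.3-fold lower number from compound 3 to compound 4 (0.63 log units; beyond the scatter) in this assay. The side piece alone can therefore give a measured number in this assay once a methyl sits in place of the hydrogen on this oxygen. Compound 3 stands at a limit, so this step has a floor but no known full size: the limit of > 100000 nM in this assay, at which 1 of the 4 values shown sits.

From the compounds shown here alone, whether a longer chain such as ethyl on that oxygen, or an amine in its place, would give a lower or higher number stays open. These compounds also cannot tell why this change lowers the number.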